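Two trimethoxyphenyl pyrazole chalcones and a dichlorophenyl analogue

The compounds below may be only part of what the source reports. "The series", "measured", "known", "first", "only" and "open" are said of these compounds alone.

Measured so far:
compound 1 `COc1cc(-c2cc(/C=C/C(=O)c3ccc(N)cc3)[nH]n2)cc(OC)c1OC` in a functional assay on MDA-MB-435 cells (Homo sapiens) for cytotoxicity, read by sulforhodamine B assay, with a stated time of 48 h, tested at 1 uM (a lower number here means a stronger effect, a higher number a weaker effect of the compound at the concentration tested), gives 88%
compound 2 `COc1ccc(-c2cc(/C=C/C(=O)c3ccc(OC)c(OC)c3)[nH]n2)cc1` in this assay gives 91%

Compound 1 and compound 2 share a pyrazole-linked enone, and in this assay their numbers lie within the usual scatter of each other, so neither can be set apart from the other on these two measurements. Both leave most of the cells growing at the concentration tested.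

Compound 3 `COc1cc(-c2cc(/C=C/C(=O)c3ccc(Cl)c(Cl)c3)[nH]n2)cc(OC)c1OC` has not yet been measured. It differs from compound 1 in one place: 3,4-dichlorophenyl in place of 4-aminophenyl on a carbonyl carbon. For the measured compounds named here, no pair of measured compounds shows what such a change does in this assay, so no measured step can guide the expectation. The step of a number 4 percentage points lower from compound 1 to compound 3 (within the scatter) is therefore expected to be small, possibly none beyond the scatter, with a slight lean toward a stronger effect. For compound 3 the estimate in this assay is 84%, with a range from 62% to 100%.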

Compound 3, a percentage reported as activity, at one concentration (the size of the read-out at that concentration, not a potency): 90%
Compound 3: the middle estimate sits 6 percentage points below what was measured; the range from low to high includes it.
By their numbers in this assay, from the lowest: compounds 1, 3 and 2 (each within the scatter of the next).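

In this assay the exchange of 4-aminophenyl for 3,4-dichlorophenyl on the carbonyl carbon gives a number 2 percentage points higher from compound 1 to compound 3 (within the scatter), so this first measured change at this position does not separate the two compounds. The hydrogen-bond donor and acceptor counted on the 4-aminophenyl group are absent from 3,4-dichlorophenyl, and compound 3 still gives 90%, leaving most of the cells growing at the concentration tested. No measurement at hand explains this result.

The compounds shown leave open whether any group on this carbonyl carbon can move the number beyond the scatter, for example a carboxylic acid or a morpholine ring. They also do not show what an exchange elsewhere in the core of compound 1 would do, such as a single methoxy group or a longer chain in place of the trimethoxyphenyl group.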